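Dichloro substitution and growth inhibition of melanoma cells

This account rests on a few compounds, and the source may have more. Where it says the series, first, only, none or still open, it means among the compounds named here.

Compound 1 `ClCc1cccc(Cn2cnc3ncnc(Cl)c32)c1` gives 22900 nM in a functional assay on SK-MEL-2 cells (Homo sapiens) for cytotoxicity, read by sulforhodamine B assay, with a stated time of 48 h (on this read-out higher numbers stand for weaker inhibition of growth and lower numbers for stronger inhibition of growth), and compound 2 `ClCc1ccccc1Cn1cnc2ncnc(Cl)c21` gives 19500 nM in this assay; the two values lie within the usual scatter of each other, and the difference between the two cores is not broken down here. Compound 3 `ClCc1cccc(Cn2cnc3nc(Cl)nc(Cl)c32)c1` gives 3710 nM in this assay. The change from compound 1 to compound 3 is chloro in place of hydrogen on an aromatic carbon and it made the step of a 6.2-fold lower number from compound 1 to compound 3 (0.79 log units; beyond the scatter). Compound 4 `ClCc1ccccc1Cn1cnc2nc(Cl)nc(Cl)c21` has not yet been measured. It differs from compound 2 by chloro in place of hydrogen on an aromatic carbon, the same change as that from compound 1 to compound 3, at the same place. Within the data shown here, compound 4 is therefore expected to show a step of a 5.7-fold lower number from compound 2 to compound 4 (0.76 log units; beyond the scatter) of about the size seen earlier, because the only precedent is the step of a 6.2-fold lower number from compound 1 to compound 3 (0.79 log units; beyond the scatter). Compound 4 is thus estimated at 3400 nM, within 1200 nM to 10000 nM.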

Compound 4, concentration for total growth inhibition: 5750 nM
For compound 4 the middle estimate is 1.7-fold (0.23 log units) below the measured one; measured number inside the range.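

In this assay chloro in place of hydrogen on an aromatic carbon again goes with stronger inhibition of growth, as a 3.4-fold lower number from compound 2 to compound 4 (0.53 log units; beyond the scatter) shows, so the change carries over from the core of compound 1 to the core of compound 2. The two steps cannot be told apart in size: the same change on two cores in this assay, a 6.2-fold lower number (0.79 log units; beyond the scatter) from compound 1 to compound 3 and a 3.4-fold lower number (0.53 log units; beyond the scatter) from compound 2 to compound 4, 1.8-fold (0.26 log units) apart, within the scatter of two such steps. This rests on two pairs in a single assay, so it shows that the change carried over between these two cores and says nothing about any other core.

The compounds shown leave open whether a different group on that same aromatic carbon, such as an amine or a methoxy group, would give a step of this kind. They also leave open whether bromo would match chloro there.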